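A few compounds are considered here, and "the series" means these few. Any claim that something is new, unique, unknown or untested is made for them only; others in the source may bear on it.

Compound 1 `COC(=O)c1cc(F)ccc1OC(=O)COc1cc(O)c2c(=O)cc(-c3ccccc3)oc2c1` is a conjugate in which a substituted benzoate ester is joined through an ester linkage to a shared core. In an ADME assay on cells (T-cell, Mus musculus, strain BALB/c) for cytotoxicity, read by MTT assay, with a stated time of 48 h (a lower number here means that less compound is tolerated, a higher number that more compound is tolerated), compound 1 gives 389000 nM. Two close relatives carry a different group on the benzoate ring: compound 2 `COC(=O)c1ccc(Cl)cc1OC(=O)COc1cc(O)c2c(=O)cc(-c3ccccc3)oc2c1` gives 265000 nM, and compound 3 `COC(=O)c1cc(O)ccc1OC(=O)COc1cc(O)c2c(=O)cc(-c3ccccc3)oc2c1` gives 263000 nM. The differences are small: a 1.5-fold lower number from compound 1 to compound 2 (0.17 log units; within the scatter), a 1.5-fold lower number from compound 1 to compound 3 (0.17 log units; within the scatter) and a 1.0-fold lower number from compound 2 to compound 3 (0.00 log units; within the scatter), so the three compounds cannot be told apart in this assay, and compound 1 stands among them rather than apart from them.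

Compound 4 `COC(=O)c1cc(C)ccc1OC(=O)COc1cc(O)c2c(=O)cc(-c3ccccc3)oc2c1` has not yet been measured. It differs from compound 1 by methyl in place of fluoro on an aromatic carbon. Going by the values given here, the step that bears most directly on this change is the one from compound 1 to compound 3, where a hydroxy replaced the same fluoro and gave a 1.5-fold lower number from compound 1 to compound 3 (0.17 log units; within the scatter); the chlorine exchange of a 1.5-fold lower number from compound 1 to compound 2 (0.17 log units; within the scatter) likewise stayed within the scatter. Every variation seen so far at this position has left the number essentially unchanged, so for compound 4 a step of a 1.2-fold lower number from compound 1 to compound 4 (0.07 log units; within the scatter) is expected, that is, none beyond the scatter. Compound 4 is therefore estimated at 330000 nM, with a likely range from 180000 nM to 600000 nM.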

Compound 4, half-maximal cytotoxic concentration: 306000 nM
Beside the measured number, compound 4's estimate is 1.1-fold (0.03 log units) above it; low and high end bracket the measured number.
By their numbers in this assay, from the lowest: compounds 3, 2, 4 and 1 (each within the scatter of the next).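

With methyl, a group holding carbon rather than a heteroatom now sits at this place on the benzoate ring, and the number still does not move beyond the scatter in this assay (a 1.3-fold lower number from compound 1 to compound 4 (0.10 log units; within the scatter); a 1.2-fold higher number from compound 3 to compound 4 (0.07 log units; within the scatter)). Fluoro, hydroxy and methyl at this one place therefore cannot be told apart, and exchanging the whole substituted benzoate group of compound 2 for that of compound 4 also stays within the scatter (a 1.2-fold higher number from compound 2 to compound 4 (0.06 log units; within the scatter)), so none of the four compounds stands apart. Nothing measured here offers a reason for this flat picture.

Still open, going by these compounds, is whether any group at this place can move the number beyond the scatter, for instance an amine, a carboxylic acid or a longer chain such as hexyl. All four compounds also share the same core and the same ester linkage, so these results cannot show whether the same flat picture would hold once either of those parts is changed.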